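The source may hold more compounds than are shown below. What is called first, only, known or untested is meant among the compounds shown, and "the series" means these compounds.

Two compounds from this series carry a number. Compound 1 `C=C1C(=O)[C@]23C[C@@]1(O)CC[C@H]2c1ccc(OS(=O)(=O)c2ccc(C)cc2)c(C)c1[C@@H]3Cn1cc(-c2ccccn2)nn1` gives 1970 nM in a functional assay on SW480 cells (Homo sapiens) for cytotoxicity, read by MTT assay, with a stated time of 4 days; on this read-out higher numbers stand for weaker inhibition and lower numbers for stronger inhibition. Compound 2 `C=C1C(=O)[C@]23C[C@@]1(O)CC[C@H]2c1ccc(O)c(C)c1[C@@H]3Cn1cc(-c2ccc(F)cc2)nn1` gives 250 nM in this assay, the lower of the two numbers shown; its nearest neighbour is compound 1, and that gap lies beyond the scatter. Compound 1 and compound 2 differ in two places at once, so their two values alone do not tell which change carries the gap.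

Compound 3 `C=C1C(=O)[C@]23C[C@@]1(O)CC[C@H]2c1ccc(OS(=O)(=O)c2ccc(C)cc2)c(C)c1[C@@H]3Cn1cc(-c2ccc(F)cc2)nn1` has not yet been measured in this assay. It is reached from compound 2 by a single change: (4-methylphenyl)sulfonyl in place of hydrogen on an oxygen on an aromatic ring. Compound 1 shares this same ((4-methylphenyl)sulfonyl)oxy group with compound 3 and stands weaker than compound 2, so some loss is expected from compound 2 to compound 3, though the second change between compound 1 and compound 2 leaves its size uncertain. The expected step from compound 2 to compound 3 in this assay is a 3.6-fold higher number from compound 2 to compound 3 (0.56 log units; beyond the scatter), a loss beyond the scatter. Compound 3 is therefore estimated at 900 nM in this assay, within a range from 280 nM to 2800 nM.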

Compound 3, half-maximal inhibitory concentration: 1630 nM
Compound 3: the middle estimate sits 1.8-fold (0.26 log units) below what was measured; the measured number falls inside the stated range.
By their numbers in this assay, from the lowest: compound 2; then compounds 3 and 1 (each within the scatter of the next).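

In this assay, among these compounds, the single change of hydroxy to ((4-methylphenyl)sulfonyl)oxy on the aromatic ring gives a 6.5-fold higher number from compound 2 to compound 3 (0.81 log units; beyond the scatter) with the 4-fluorophenyl group held fixed, so this change alone carries a loss beyond the scatter, something the two earlier compounds, which differ in two places at once, could not show. The other change, 4-fluorophenyl in place of pyridin-2-yl on an aromatic carbon, gives a 1.2-fold lower number from compound 1 to compound 3 (0.08 log units; within the scatter) while the ((4-methylphenyl)sulfonyl)oxy group stays in place, and that step lies within the scatter. Read together, the two steps place the gap between compound 1 and compound 2 at the group on the oxygen and not at the group on the aromatic carbon, at least while the ((4-methylphenyl)sulfonyl)oxy group is present.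

Still open, going by these compounds, is whether pyridin-2-yl and 4-fluorophenyl also match when the hydroxy group is free, and whether a smaller group on that oxygen, such as methyl or acetyl, would bring the same loss as (4-methylphenyl)sulfonyl. Nothing measured here explains why the loss occurs.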